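The source may report more compounds than this note shows. Statements on the series, on what has been measured and on what is new or still open speak of the compounds shown alone.

In an assay on isolated protein for inhibition of thyroid hormone receptor beta (Homo sapiens), read by fluorescence, with a stated time of 30 min (on this read-out higher numbers stand for weaker inhibition and lower numbers for stronger inhibition), three compounds with the shared core of compound 1 `COc1cc(C(=O)N2CCC(O)C(C)C2)cc2nc(NCc3cc(Cl)ccc3F)oc12` have been measured. Compound 1 gives 300 nM, and compound 2 `COc1cc(C(=O)N2CCC(O)C(C)C2)cc2nc(NCc3cc(Cl)ccc3O)oc12` gives 170 nM; the step of a 1.8-fold lower number from compound 1 to compound 2 (0.25 log units; within the scatter) shows these two close together. Compound 3 `COc1cc(C(=O)N2CCC(O)C(C)C2)cc2nc(N[C@@H](C)c3cccc(Cl)c3)oc12` gives 5100 nM, the highest of the three numbers. The step of a 17-fold higher number from compound 1 to compound 3 (1.23 log units; beyond the scatter) and the step of a 30-fold higher number from compound 2 to compound 3 (1.48 log units; beyond the scatter) both show that replacing the substituted benzyl group on the nitrogen of the core with 1-(3-chlorophenyl)ethyl moves the number strongly upward.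

Compound 4 `COc1cc(C(=O)N2CCC(O)C(C)C2)cc2nc(NC3(c4cccc(Cl)c4)CC3)oc12` is the next compound to be measured. It differs from compound 3 in one place: 1-(3-chlorophenyl)cyclopropyl in place of 1-(3-chlorophenyl)ethyl on a nitrogen on an aromatic ring. Going by the values given here, no measured step tests this particular exchange, since the two large steps to compound 3 changed the whole group on that nitrogen, not only the carbon that carries the ring. What those steps do show is that this position can move the number a long way in this assay.

Without a direct precedent, the step of a 1.5-fold lower number from compound 3 to compound 4 (0.16 log units; within the scatter) is expected to be modest, with no clear direction beyond the scatter. Compound 4 is therefore estimated at 3500 nM, in a range from 900 nM to 14000 nM.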

Compound 4, half-maximal inhibitory concentration: 120 nM
Beside the measured number, compound 4's estimate is 29-fold (1.46 log units) above it, outside the stated range (below it).
By their numbers in this assay, from the lowest: compounds 4, 2 and 1 (each within the scatter of the next, the first and the last beyond it); then compound 3.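

Exchanging 1-(3-chlorophenyl)ethyl for 1-(3-chlorophenyl)cyclopropyl keeps the 3-chlorophenyl ring and still produces a 43-fold lower number from compound 3 to compound 4 (1.63 log units; beyond the scatter) in this assay, so a change confined to the carbon that carries the ring can matter as much here as replacing the whole group on the nitrogen. Compound 4 also shows that a substituted carbon at this place does not by itself go with a high number: the step is a 1.4-fold lower number from compound 2 to compound 4 (0.15 log units; within the scatter), which leaves the two compounds level, while the other comparison with a benzyl compound is a 2.5-fold lower number from compound 1 to compound 4 (0.40 log units; beyond the scatter) and counts as a modest gain. No supporting measurement is available to explain why the three-membered ring gives so different a number from the ethyl group.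

As far as these compounds go, it remains open whether other groups on that carbon, such as a cyclobutyl ring or two methyl groups, would follow the cyclopropyl or the ethyl compound, and how the mirror-image form of compound 3 would compare. Also open, from the compounds shown here alone, is whether a hydroxy or fluoro group on the aromatic ring of compound 4 would change its number.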